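This account rests on a few compounds, and the source may have more. Where it says the series, first, only, none or still open, it means among the compounds named here.

Working notes on the series. The three measured analogues share one core: compound 1 `COc1ccc(-c2cc(/C=C/C(=O)c3ccc(N)cc3)[nH]n2)cc1`, compound 2 `COc1cc(-c2cc(/C=C/C(=O)c3ccc(N)cc3)[nH]n2)cc(OC)c1OC` and compound 3 `COc1cc(-c2cc(/C=C/C(=O)c3ccc(Cl)c(Cl)c3)[nH]n2)cc(OC)c1OC`. In a functional assay on SN12C cells (Homo sapiens) for cytotoxicity, read by sulforhodamine B assay, with a stated time of 48 h, tested at 0.1 uM (a higher number here means a weaker effect of the compound at the concentration tested, a lower number a stronger effect), compound 2 gives 99%, compound 3 gives 96% and compound 1 gives 94%; the three numbers lie within the scatter of one another, so no order among them can be read. Going by the values given here, the one single-point step measured so far, a number 3 percentage points lower from compound 2 to compound 3 (within the scatter), likewise shows no movement.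

Compound 4 `COc1ccc(-c2cc(/C=C/C(=O)c3ccc(N)cc3)[nH]n2)cc1OC` differs from compound 2 by hydrogen in place of methoxy on an aromatic carbon. Among the compounds with values here, no measured step touches this position; the only guide is that every measured value sits near the top of the scale. The step from compound 2 to compound 4 in this assay is therefore expected to be none beyond the scatter, a number 3 percentage points lower from compound 2 to compound 4 (within the scatter). For compound 4 the expected value is 96%, in the range 86% to 103%.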

Compound 4, a percentage reported as activity, at one concentration (the size of the read-out at that concentration, not a potency): 99%
The estimate for compound 4 lay 3 percentage points below the measured number; the range from low to high includes it.
By their numbers in this assay, from the lowest: compounds 1, 3, 2 and 4 (each within the scatter of the next).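

In this assay, the aromatic carbon ortho to a methoxy group and meta to a large group now has measured steps: hydrogen in place of methoxy gives no change at the digits printed from compound 2 to compound 4 (within the scatter), and methoxy in place of hydrogen gives a number 5 percentage points higher from compound 1 to compound 4 (within the scatter). Going by these compounds alone, at this single concentration, the exchange between hydrogen and methoxy at this position therefore shows no movement in either step. Nothing available bears on why the read-out stays put. From the compounds shown here alone, whether an amine or a carboxylic acid on this carbon would move the read-out remains open. Also open, going by these compounds, is whether the exchange between hydrogen and methoxy has any effect at a higher concentration.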